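Swapping an aromatic ring for a saturated one

The compounds below may be only part of what the source reports. "The series", "measured", "known", "first", "only" and "open" are said of these compounds alone.

Three compounds share one core. Compound 1 `FC(F)(F)c1cccc(-c2nc3cnc(Nc4ccncn4)cc3[nH]2)c1`, compound 2 `Fc1ccc(-c2nc3cnc(Nc4ccc(C(F)(F)F)cn4)cc3[nH]2)cc1F` and compound 3 `Fc1ccc(Nc2cc3[nH]c(-c4ccc(F)c(F)c4)nc3cn2)nc1` were each tested in an ADME assay on microsomes from liver (Rattus norvegicus) for metabolic stability, read by LC-MS, with a stated time of 30 min, tested at 0.1 uM; on this read-out lower numbers stand for a less stable compound and higher numbers for a more stable compound. Compound 2 gives 89%; compound 1 gives 88% and compound 3 gives 79%, and neither differs from compound 2 by more than the usual scatter. Within the data shown here, the one single-point step, a number 10 percentage points lower from compound 2 to compound 3 (within the scatter), concerns a different part of the molecule. Compound 4 `FC(F)(F)c1ccc(Nc2cc3[nH]c([C@H]4CC[C@H](C(F)(F)F)CC4)nc3cn2)nc1` arises from compound 2 by 4-(trifluoromethyl)cyclohexyl in place of 3,4-difluorophenyl on an aromatic carbon. Among the measured compounds shown here, no measured step touches this kind of change, so the only guide is that all three measured compounds sit high. Compound 4 is therefore expected near compound 2 with wider uncertainty, an estimated 78% (range 55% to 93%), meaning an expected step of a number 11 percentage points lower from compound 2 to compound 4 (beyond the scatter).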

Compound 4, percent of the compound remaining: 64%
Estimate against measurement, compound 4: 14 percentage points above; low and high end bracket the measured number.
By their numbers in this assay, from the lowest: compound 4; then compounds 3, 1 and 2 (each within the scatter of the next).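

In this assay, among these compounds, the step of a number 25 percentage points lower from compound 2 to compound 4 (beyond the scatter) is the first single-place change here to go beyond the scatter, so the group on this carbon between two ring nitrogen atoms does matter for this read-out. The step of a number 10 percentage points lower from compound 2 to compound 3 (within the scatter), in a different part of the molecule, stayed within the scatter. This change replaces the aromatic ring and its substituents together, so the compounds shown cannot separate the two. Still open, as far as these compounds go, is whether plain cyclohexyl or a piperidine ring would behave like 4-(trifluoromethyl)cyclohexyl at this place. No measurement here gives a reason for the drop.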